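Aryl swap at the carbon with a double bond to nitrogen

The source may report more compounds than this note shows. Statements on the series, on what has been measured and on what is new or still open speak of the compounds shown alone.

Among the compounds with values here, compound 1 `CS(=O)(=O)c1ccc(Cc2nnc3n2N=C(c2cc(Cl)sc2S(N)(=O)=O)CS3)cc1` is the only member of the series with a number so far: in a functional assay on HT-29 cells (Homo sapiens) for cytotoxicity, read by MTT assay, with a stated time of 48 h, tested at 25 uM (on this read-out higher numbers stand for a stronger effect at the one concentration tested and lower numbers for a weaker effect), compound 1 gives 18.7%, a weak effect at the one concentration. Within the data shown here, compound 2 `CS(=O)(=O)c1ccc(Cc2nnc3n2N=C(c2cc(Cl)sc2Cl)CS3)cc1` is reported in this assay as "not active" (no number reported), without a number attached, so the two values together show only that neither compound reaches a strong effect. Among the measured compounds shown here, no step between two measured compounds exists, and nothing shows yet how a change at the carbon with a double bond to nitrogen moves the read-out.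

Compound 3 `Cc1ccc(C2=Nn3c(Cc4ccc(S(C)(=O)=O)cc4)nnc3SC2)cc1` differs from compound 1 by 4-methylphenyl in place of 5-chloro-2-sulfamoylthiophen-3-yl on a carbon with a double bond to nitrogen. With both measured compounds weak, the step is expected to be no larger than the scatter and, if anything, downward, because compound 1 gives only 18.7%; the estimated step is a number 6.7 percentage points lower from compound 1 to compound 3 (within the scatter). Compound 3 is therefore estimated at 12%, in a range from 0% to 30%, with a fair chance that it is reported without a number.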

Compound 3, a percentage reported as activity, at one concentration (the size of the read-out at that concentration, not a potency): 1.26%
Compound 3: the middle estimate sits 10.7 percentage points above what was measured, within the range that was stated.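

In this assay, within the data shown here, the step of a number 17.4 percentage points lower from compound 1 to compound 3 (beyond the scatter) is the first readable change at this position, and it shows that the read-out responds to the aryl group on the carbon with a double bond to nitrogen, even from a low starting value. The swap replaces 5-chloro-2-sulfamoylthiophen-3-yl, with its hydrogen-bond donor and acceptors, by 4-methylphenyl, which has neither, so several features change at once and the step cannot be assigned to any one of them. Nothing measured here explains the step.

Compound 2 has no number, so steps involving it cannot be read. Still open, as far as these compounds go, is whether a thiophene carrying a carboxylic acid or an amine in place of the sulfamoyl group would keep the effect seen with compound 1 or lose it as compound 3 does.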